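The source may hold more compounds than are shown below. What is called first, only, known or untested is meant among the compounds shown, and "the series" means these compounds.

Three analogues around a shared arylpiperazine motif have been measured. Compound 1 `Nc1ncnc(N2CCN(c3cccc(Cl)c3)CC2)c1[N+](=O)[O-]` gives 85 nM in an assay for inhibition of ribosomal protein S6 kinase beta-1 variant D18H,T412E (Homo sapiens), read by a luciferase reporter and chemiluminescence, with a stated time of 3 h; a lower number here means a stronger inhibitor, a higher number a weaker inhibitor. Compound 2 `Cc1ccc(Cl)cc1N1CCN(c2ncnc(N)c2[N+](=O)[O-])CC1` gives 3 nM. The change between them, (methyl in place of hydrogen on an aromatic carbon), produces a 28-fold lower number from compound 1 to compound 2 (1.45 log units; beyond the scatter). Compound 3 `Cc1ccc(Cl)cc1N1CCN(c2ncnc3[nH]ncc23)CC1` carries a different core; the difference between the two cores is not broken down here. Compound 3 gives 13 nM, which sits between the other two values.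

Compound 4 `Cc1ccc(Cl)cc1N1CCN(c2ncnc3[nH]nc(C)c23)CC1` is not yet measured. It differs from compound 3 by methyl in place of hydrogen on an aromatic carbon. This is the same kind of change as in the earlier pair, but the place is not the same: there the methyl entered on a six-membered aromatic ring of carbon only, ortho to a large group and para to a chloro group; here it enters on a five-membered aromatic ring with 2 nitrogen, part of a fused system, next to the ring nitrogen. Going by the values given here, only one earlier instance exists, and it sits in a different part of the molecule, so a step of the same size is not assumed. Among the compounds with values here, from compound 3 to compound 4 a step of a 2.2-fold lower number from compound 3 to compound 4 (0.34 log units; beyond the scatter) is expected, smaller than the earlier 28-fold lower number from compound 1 to compound 2 (1.45 log units; beyond the scatter), resting on the fact that the single precedent concerns a different place. Compound 4 is expected to give about 6 nM, within 2 nM to 20 nM.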

Compound 4, half-maximal inhibitory concentration: 9 nM
Estimate against measurement, compound 4: 1.5-fold (0.18 log units) below; the range from low to high includes it.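

In this assay, methyl in place of hydrogen on an aromatic carbon does not carry a fixed size of step from one core to another: the same change on two cores in this assay, a 28-fold lower number (1.45 log units; beyond the scatter) from compound 1 to compound 2 and a 1.4-fold lower number (0.16 log units; within the scatter) from compound 3 to compound 4, 20-fold (1.29 log units) apart, beyond the scatter of two such steps. On the five-membered aromatic ring of the core of compound 3, the change gives a 1.4-fold lower number from compound 3 to compound 4 (0.16 log units; within the scatter), so this pair shows no gain from the methyl. The two pairs do not separate the effect of the core from that of the place, as the methyl enters a different ring in each, and two pairs support no general rule for the series.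

The compounds shown leave open how much the methyl on the six-membered ring contributes on the core of compound 3, which would take the partner of compound 3 with hydrogen at that carbon. They also leave open whether a group other than methyl, such as ethyl, an amine or a nitrile, on the same aromatic carbon of the five-membered ring would give a step beyond the scatter.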